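The source may report more compounds than this note shows. Statements on the series, on what has been measured and on what is new or still open speak of the compounds shown alone.

Working notes on the series. Compound 1 `COc1ccccc1-c1ncnn1-c1cc(OC)c(OC)c(OC)c1` carries a 2-methoxyphenyl on the shared core. In a functional assay on A549 cells (Homo sapiens) for antiproliferative activity, read by MTT assay, with a stated time of 72 h (a lower number here means a stronger inhibitor, a higher number a weaker inhibitor), compound 1 gives > 10000 nM, which is a limit of the assay and not a number. Compound 2 `COc1cc(-c2ncnn2-c2cccc(N)c2)cc(OC)c1OC` and compound 3 `COc1ccc(-n2ncnc2-c2cc(OC)c(OC)c(OC)c2)cc1` share the core but differ on the aromatic nitrogen. In this assay compound 2 gives > 10000 nM, a limit. In this assay compound 3 gives > 10000 nM, again a limit. For the measured compounds named here, the single step between measured compounds, a step that the two limits leave unreadable from compound 2 to compound 3, is therefore unreadable. On the numbers shown compound 1 stands at a limit, as do both other compounds: the limit of > 10000 nM in this assay, at which 3 of the 3 values shown sit.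

Compound 4 `COc1cc(-n2ncnc2-c2ccc(C)cc2)cc(OC)c1OC` is not yet measured. It differs from compound 1 as follows: 4-methylphenyl in place of 2-methoxyphenyl on an aromatic carbon. Going by the values given here, no measured step concerns this position on the core; the only measured step concerns the aromatic nitrogen and its size is not readable. Nothing shown therefore supports any expected shift beyond the scatter in this assay, in either direction. Since compound 1 sits at a limit, compound 4 is expected most likely to return a limit as well. The expected step, a step that the limit leaves unreadable from compound 1 to compound 4, is essentially none. Compound 4 is expected at 15000 nM, within a range of 5000 nM to 60000 nM.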

Compound 4, half-maximal inhibitory concentration: 1100 nM
Estimate against measurement, compound 4: 14-fold (1.13 log units) above; the whole stated range lies above it.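

For the compounds shown here, with 4-methylphenyl in place of 2-methoxyphenyl, this position on the shared core gives the first readable change: in this assay the step is an at least 9.0-fold lower number from compound 1 to compound 4 (0.95 log units; beyond the scatter). For compound 1 the value of > 10000 nM is a limit and not a number, so this step has a bound but no exact size. The earlier compounds gave no sign that any change could bring a value within the range of the assay, and compound 4 is the only one here with a readable number: the limit of > 10000 nM in this assay, at which 3 of the 4 values shown sit.

The change replaces the methoxy group with a methyl group and also moves the substituent on the phenyl ring, and the compounds shown do not separate these two differences, since neither 4-methoxyphenyl nor 2-methylphenyl appears at this position on the core of compound 1. As far as these compounds go, it also remains open how 4-aminophenyl, 4-chlorophenyl or 4-ethylphenyl would read at this position, and the step on the aromatic nitrogen still cannot be read.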